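Cyano for trifluoromethyl on a scaffold without measured cytotoxicity

The compounds below may be only part of what the source reports. "The series", "measured", "known", "first", "only" and "open" are said of these compounds alone.

Three compounds of this series have been examined in an ADME assay on HeLa cells (Homo sapiens) for cytotoxicity, read by ATP content, with a stated time of 3 days; on this read-out lower numbers stand for higher toxicity in this test and higher numbers for lower toxicity in this test. In this assay compound 1 `O=c1n(Cc2cc3cc(Cl)ccc3n2CCCC(F)(F)F)c2cnccc2n1C1CC1` reaches only a limit, > 50000 nM. Compound 2 `CC(C)CCn1c(Cn2c(=O)n(C3CC3)c3ccncc32)nc2ccncc21` also gives only a limit in this assay, > 100000 nM. Compound 3 `O=c1n(Cc2nc3ncccc3n2CCCCO)c2cnccc2n1C1CC1` likewise gives only a limit in this assay, > 100000 nM. None of the three readings is a number: two of them sit at the limit of > 100000 nM in this assay, at which 2 of the 3 values shown sit, and one at the limit of > 50000 nM in this assay, at which 1 of the 3 values shown sits. Within the data shown here, compound 1 therefore stands among compounds that all show no measurable cytotoxicity in this assay, and no step between any two of them can be reckoned.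

Compound 4 `N#CCCCn1c(Cn2c(=O)n(C3CC3)c3ccncc32)cc2cc(Cl)ccc21` is the next compound, not yet measured in this assay. It differs from compound 1 in one place: cyano in place of trifluoromethyl on a saturated chain carbon, three bonds along the chain from an aromatic nitrogen. Among the measured compounds shown here, with no measured step to guide the size of this change, the expectation is of no step beyond the usual scatter, and the expected step from compound 1 to compound 4 in this assay is a step that the limit leaves unreadable from compound 1 to compound 4. Compound 4 is thus estimated at 70000 nM, in the range 20000 nM to 200000 nM, with a strong chance that the assay again reports only a limit.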

Compound 4, half-maximal cytotoxic concentration: > 50000 nM
Compound 4 gave a limit, no number; the forecaster's own chance of this, stated with the estimate: 85%; the middle value lies beyond the limit too.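

Compound 1 and compound 4 each give only a limit in this assay, so no step can be read between them. The compounds shown leave open whether cyano in place of trifluoromethyl on this chain changes cytotoxicity at all, and by how much.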